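Removing One Methyl: Methoxy to Hydroxy in Compound 4

A few compounds are considered here, and "the series" means these few. Any claim that something is new, unique, unknown or untested is made for them only; others in the source may bear on it.

Compound 1 `COc1cc(-c2nn(-c3cccc(NC(=O)c4ccc(Cl)c(C(F)(F)F)c4)c3)cc2-c2ccncc2)ccc1Cl` gives 1380 nM in a functional assay on SF-295 cells (Homo sapiens) for inhibition, read by sulforhodamine B assay, with a stated time of 48 h; a higher number here means a weaker inhibitor of growth, a lower number a stronger inhibitor of growth.
Compound 2 `O=C(Nc1cccc(-n2cc(-c3ccncc3)c(-c3ccc(Cl)c(O)c3)n2)c1)Nc1cc(C(F)(F)F)cc(C(F)(F)F)c1` gives 618 nM in this assay.
Compound 3 `COc1cc(-c2nn(-c3cccc(NC(=O)Nc4cccc(C(F)(F)F)c4)c3)cc2-c2ccncc2)ccc1Cl` gives 306 nM in this assay.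

Among these three numbers, compound 3 has the lowest. Among the measured compounds shown here, the one measured step leading to it, a 4.5-fold lower number from compound 1 to compound 3 (0.65 log units; beyond the scatter), sets it apart from compound 1, and its distance from compound 2 is also beyond the scatter. Compound 4 `O=C(Nc1cccc(-n2cc(-c3ccncc3)c(-c3ccc(Cl)c(O)c3)n2)c1)Nc1cccc(C(F)(F)F)c1` differs from compound 3 in a single place: hydrogen in place of methyl on an oxygen on an aromatic ring. For the measured compounds named here, no measured pair differs in exactly this way, so no step speaks to it directly. Going by the values given here, compound 2 carries the same hydroxy group as compound 4, but it also differs from compound 3 at a second place, so its value shows only that a hydroxy-bearing compound can land in the same general region as compound 3. For compound 4 the expected step is therefore a 1.1-fold higher number from compound 3 to compound 4 (0.06 log units; within the scatter), nothing beyond the scatter. The estimate for compound 4 in this assay is 350 nM, with a range from 150 nM to 800 nM.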

Compound 4, concentration for 50% growth inhibition: 962 nM
Estimate against measurement, compound 4: 2.7-fold (0.44 log units) below, and the stated range ends below it.
By their numbers in this assay, from the lowest: compound 3; then compounds 2, 4 and 1 (each within the scatter of the next, the first and the last beyond it).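

Among the compounds shown here, this pair gives the first direct reading of the methoxy to hydroxy change on the 4-chloro-3-methoxyphenyl group: in this assay it appears as a 3.1-fold higher number from compound 3 to compound 4 (0.50 log units; beyond the scatter), so here the methyl on this oxygen cannot be swapped for hydrogen without a measurable shift. With the hydroxy group in place, the second trifluoromethyl group does not separate the two compounds, as a 1.6-fold higher number from compound 2 to compound 4 (0.19 log units; within the scatter) shows. Nothing measured here gives a reason for either step.

On these data alone, it remains open whether the methoxy to hydroxy change would give a similar shift in a compound carrying both trifluoromethyl groups, or in an amide such as compound 1. How an ethoxy group or an amine would read on this aromatic carbon is also unknown from these compounds.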